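A few compounds are considered here, and "the series" means these few. Any claim that something is new, unique, unknown or untested is made for them only; others in the source may bear on it.

Of the compounds shown here, two have so far been tested in a functional assay on the whole organism (Abdomen, strain Swiss) for inhibition, with Mus musculus as the target, with stated times of 30 min, 10 min and 5 min, at a dose of 10 mg/kg by the oral route; a higher number here means a stronger effect of the compound at the dose given, a lower number a weaker effect. Compound 1, `CC/C=C/c1c(C)nn(CCCN2CCN(c3ccc(C)cc3)CC2)c(=O)c1N`, gives 5% in this assay. Compound 2, `Cc1c(C#N)c(-c2ccccc2)nn1CCCN1CCN(c2ccc(F)cc2)CC1`, gives 9% in this assay. The gap between these two numbers lies within the usual scatter of repeated measurements, so neither compound can be said to act more strongly than the other; both readings are small, and compound 2 simply sits alongside compound 1.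

Compound 3, `COc1cccc(N2CCN(CCCn3nc(-c4ccccc4)c(C#N)c3C)CC2)c1`, has not yet been measured. It differs from compound 2 in one place: 3-methoxyphenyl in place of 4-fluorophenyl on an amine nitrogen in a ring. For the measured compounds named here, no measured pair of compounds shows what a change of this kind does in this assay, so the only guide is that both measured compounds give small readings at the dose used.

On that basis the change is expected to give a step of about a number 1 percentage points lower from compound 2 to compound 3 (within the scatter), which lies within the scatter and has no clear direction. For compound 3 the reading in this assay is estimated at 8%, with a likely range from 0% to 20%.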

Compound 3, a percentage reported as inhibition, in the whole organism at one dose (the size of the read-out at that dose, not a potency): 0%
Compound 3: middle estimate off by 8 percentage points, on the high side; low and high end bracket the measured number.
By their numbers in this assay, from the lowest: compounds 3, 1 and 2 (each within the scatter of the next).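

For the compounds shown here, this is the first measured pair of compounds that differ in one place, and in this assay putting 3-methoxyphenyl in place of 4-fluorophenyl on the amine nitrogen in a ring gives a step of a number 9 percentage points lower from compound 2 to compound 3 (within the scatter). The 3-methoxyphenyl group brings an oxygen and a hydrogen-bond acceptor that 4-fluorophenyl lacks, yet the readings of the two compounds cannot be told apart, so this change shows no clear effect at this position at the dose used. No measurement at hand bears on why the readings look like this.

The change alters both the group on the phenyl ring and where that group sits, so a 3-fluorophenyl or a 4-methoxyphenyl group on the same nitrogen would be needed to separate the two. From the compounds shown here alone, whether any group at this position, such as a plain phenyl or a 4-chlorophenyl, can lift the reading clearly out of the small range seen so far also stays open.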